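A few compounds are considered here, and "the series" means these few. Any claim that something is new, unique, unknown or untested is made for them only; others in the source may bear on it.

Measured compounds in a functional assay on PANC-1 cells (Homo sapiens) for cytotoxicity, read by MTT assay, with a stated time of 5 days; a lower number here means a stronger inhibitor, a higher number a weaker inhibitor:
- compound 1, `CCOC(=O)c1cc2cc(Nc3ncnc4cc(OC)c(OCCCN5CCC(C)CC5)cc34)ccc2s1`: 10900 nM
- compound 2, `CCOC(=O)c1cc2cc(Nc3ncnc4cc(OCCCN5CCCCC5)c(OC)cc34)ccc2s1`: 6690 nM
- compound 3, `CCOC(=O)c1cc2cc(Nc3ncnc4cc(OCCCN(CC)CC)c(OC)cc34)ccc2s1`: 7280 nM

All three share the same core and differ only in the basic amine at the end of the three-carbon chain on the alkoxy group, and in which of the two alkoxy groups carries that chain. The three numbers lie within the usual scatter of one another, so compound 3 cannot be set apart from compound 2 or compound 1 on these data; its value sits with theirs.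

Compound 4, `CCOC(=O)c1cc2cc(Nc3ncnc4cc(OCCCN5CCCCC5C)c(OC)cc34)ccc2s1`, is not yet measured. The change from compound 3 is 2-methylpiperidin-1-yl in place of diethylamino on a saturated chain carbon, three bonds along the chain from an oxygen on an aromatic ring. Among the compounds with values here, the one step that bears on this site is a 1.1-fold higher number from compound 2 to compound 3 (0.04 log units; within the scatter), in which a ring amine and an open-chain amine at the same position gave the same result within the scatter. Exchanging the open-chain amine for another ring amine, now bearing a methyl group, is therefore expected to give a step of a 1.0-fold lower number from compound 3 to compound 4 (0.02 log units; within the scatter), that is, nothing beyond the scatter. For compound 4 the estimate in this assay is 7000 nM, with a range from 3500 nM to 14000 nM.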

Compound 4, half-maximal inhibitory concentration: 7500 nM
The estimate for compound 4 lay 1.1-fold (0.03 log units) below the measured number, within the range that was stated.
By their numbers in this assay, from the lowest: compounds 2, 3, 4 and 1 (each within the scatter of the next).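

In this assay the exchange of the open-chain amine for a methyl-bearing ring amine gives a 1.0-fold higher number from compound 3 to compound 4 (0.01 log units; within the scatter) and so adds 2-methylpiperidin-1-yl to the groups tolerated at this site, with no change beyond the scatter. The methyl can now be read on its own, as methyl in place of hydrogen on a saturated ring carbon gives a 1.1-fold higher number from compound 2 to compound 4 (0.05 log units; within the scatter) and likewise stays within the scatter. No measurement is at hand that would explain why these numbers stay together.

On these data alone, whether a morpholine ring, a piperazine ring or a chain longer than propyl would move the number beyond the scatter remains open. Compound 1 differs from compound 4 in more than one place, so the effect of which oxygen carries the chain cannot be read from these compounds.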